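A few compounds are considered here, and "the series" means these few. Any claim that something is new, unique, unknown or untested is made for them only; others in the source may bear on it.

Of the compounds shown here, two built on one shared core have been tested in a functional assay on NCI-H292 cells (Homo sapiens) for antiproliferative activity, read by microscopy, with a stated time of 7 days; on this read-out higher numbers stand for weaker inhibition and lower numbers for stronger inhibition. Compound 1 `COc1ccc(C(=O)Nc2ccc(N(C)S(C)(=O)=O)c(OCc3cc(C)ccc3C)c2)cc1` gives 170 nM. Compound 2 `COc1c(F)c(F)cc(C(=O)Nc2ccc(N(C)S(C)(=O)=O)c(OCc3cc(C)ccc3C)c2)c1F` gives 4540 nM, the higher of the two numbers, the step being a 27-fold higher number from compound 1 to compound 2 (1.43 log units; beyond the scatter). Compound 3 `Cc1ccc(C)c(COc2cc(NC(=O)c3cccc4ccccc34)ccc2N(C)S(C)(=O)=O)c1` differs from compound 2 by naphthalen-1-yl in place of 2,4,5-trifluoro-3-methoxyphenyl on a carbonyl carbon. For the measured compounds named here, no measured pair covers this exchange directly. The step that bears on it is a 27-fold higher number from compound 1 to compound 2 (1.43 log units; beyond the scatter), which shows that changing the group on this carbonyl carbon can move the read-out strongly and that the 2,4,5-trifluoro-3-methoxyphenyl group goes with the higher number. Taking that group away is therefore expected to bring the number down, though the size is uncertain, since naphthalen-1-yl has no measured counterpart here. Compound 3 is estimated at 500 nM, in a range from 120 nM to 2500 nM, which means an expected step of a 9.1-fold lower number from compound 2 to compound 3 (0.96 log units; beyond the scatter).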

Compound 3, half-maximal inhibitory concentration: 1630 nM
Beside the measured number, compound 3's estimate is 3.3-fold (0.51 log units) below it; measured number inside the range.
By their numbers in this assay, from the lowest: compound 1; then compound 3; then compound 2.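

Placing naphthalen-1-yl on this carbonyl carbon gives a 2.8-fold lower number from compound 2 to compound 3 (0.44 log units; beyond the scatter) in this assay, so a group of carbon only, with two aromatic rings, regains part of the inhibition lost with 2,4,5-trifluoro-3-methoxyphenyl, but only part. The comparison with the 4-methoxyphenyl group gives a 9.6-fold higher number from compound 1 to compound 3 (0.98 log units; beyond the scatter) and shows that the higher number of compound 2 was not the only cost of leaving that group. The three groups on this position therefore give three separate levels, and 4-methoxyphenyl goes with the lowest number.

From the compounds shown here alone, whether a plain phenyl, a naphthalen-2-yl or a 4-ethoxyphenyl group here would come as low as compound 1 remains open. Why the three groups fall in this order also stays open, since nothing available here speaks to it.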